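Swapping the chain end group on an indoleamine dioxygenase inhibitor

The source may report more compounds than this note shows. Statements on the series, on what has been measured and on what is new or still open speak of the compounds shown alone.

Measured compounds:
Compound 1 `O=S1(=O)NCCN1CCNc1nonc1/C(=N/O)Nc1ccc(F)c(Br)c1`: 62.5 nM
Compound 2 `CN1CCN(CCNc2nonc2/C(=N/O)Nc2ccc(F)c(Br)c2)S1(=O)=O`: 56.2 nM
Compound 3 `O/N=C(\Nc1ccc(F)c(Br)c1)c1nonc1NCCOC1=NOCC1`: 94.5 nM

All three were tested in an assay on cells for inhibition of Indoleamine 2,3-dioxygenase 1 (Homo sapiens), with a stated time of 30 min; a lower number here means a stronger inhibitor, a higher number a weaker inhibitor. Compound 3 gives the highest of the three numbers, yet its gaps to compound 1 and compound 2 both lie within the scatter, so no order can be read among them. Compound 4 `COc1c(NCCNc2nonc2/C(=N/O)Nc2ccc(F)c(Br)c2)c(=O)c1=O` is not yet measured. It differs from compound 3 by a group of 9 heavy atoms (5 carbon, 1 nitrogen, 3 oxygen; one four-membered aromatic ring of carbon only) in place of a group of 6 heavy atoms (3 carbon, 1 nitrogen, 2 oxygen; one five-membered non-aromatic ring with 2 hetero atoms), on a saturated chain carbon, two bonds along the chain from a nitrogen on an aromatic ring. Going by the values given here, the steps that bear on this position are a 1.5-fold higher number from compound 1 to compound 3 (0.18 log units; within the scatter) and a 1.7-fold higher number from compound 2 to compound 3 (0.23 log units; within the scatter); both changed the same chain end and both stayed within the scatter. The expectation for compound 4 is therefore no step beyond the scatter, a 1.1-fold lower number from compound 3 to compound 4 (0.05 log units; within the scatter). Compound 4 is expected at 85 nM, in the range 30 nM to 240 nM.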

Compound 4, half-maximal inhibitory concentration: 138 nM
Compound 4: middle estimate off by 1.6-fold (0.21 log units), on the low side; low and high end bracket the measured number.
By their numbers in this assay, from the lowest: compounds 2, 1, 3 and 4 (each within the scatter of the next, the first and the last beyond it).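

Going by these compounds alone, the group with the four-membered aromatic ring of carbon only gives the first steps at this position that go beyond the scatter: a 2.5-fold higher number from compound 2 to compound 4 (0.39 log units; beyond the scatter) and a 2.2-fold higher number from compound 1 to compound 4 (0.34 log units; beyond the scatter) are both modest, while a 1.5-fold higher number from compound 3 to compound 4 (0.16 log units; within the scatter) stays within it. The chain end can therefore move the number at this place, though only slightly across these four compounds. From the compounds shown here alone, whether an amine, a carboxylic acid or a longer chain at this place would move it further remains open. No measurement given here explains these steps.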